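A few compounds are considered here, and "the series" means these few. Any claim that something is new, unique, unknown or untested is made for them only; others in the source may bear on it.

Within the data shown here, compound 2 `O=C(Nc1ccncc1)c1c(O)c2cccnc2n(-c2ccccc2)c1=O` gives 34.9% in a functional assay on the whole organism for inhibition, with Rattus norvegicus as the target, read by paw edema, at a dose of 100 mg/kg by the oral route (a lower number here means less inhibition, a higher number more inhibition at the dose given (going by the name of the read-out)), the higher of the two numbers so far. Compound 1 `Nc1ccc(NC(=O)c2c(O)c3cccnc3n(-c3ccccc3)c2=O)cc1` gives -5.5%, the step of a number 40.4 percentage points higher from compound 1 to compound 2 (beyond the scatter). Compound 3 `O=C(NCc1cccnc1)c1c(O)c2cccnc2n(-c2ccccc2)c1=O` differs from compound 2 by (pyridin-3-yl)methyl in place of pyridin-4-yl on an amide-type nitrogen. Among the measured compounds shown here, the one measured step concerns a different exchange at the same amide-type nitrogen and does not bear directly on this one; nothing measured tells how trading one of these groups for the other acts. A step of a number 7.9 percentage points lower from compound 2 to compound 3 (within the scatter) is therefore expected, one that need not exceed the scatter. The estimate for compound 3 in this assay is 27%, ranging from 5% to 48%.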

Compound 3, a percentage reported as inhibition, in the whole organism at one dose (the size of the read-out at that dose, not a potency): 25.5%
For compound 3 the middle estimate is 1.5 percentage points above the measured one, within the range that was stated.
By their numbers in this assay, from the lowest: compound 1; then compounds 3 and 2 (each within the scatter of the next).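

In this assay, (pyridin-3-yl)methyl in place of pyridin-4-yl on the amide-type nitrogen gives a number 9.4 percentage points lower from compound 2 to compound 3 (within the scatter) and so shows that this position accepts this change without a step beyond the scatter. Against 4-aminophenyl, the same group gives a number 31 percentage points higher from compound 1 to compound 3 (beyond the scatter) and so shows that the large step first seen at this nitrogen is not confined to pyridin-4-yl. Nothing available explains either step. The compounds shown leave open whether (pyridin-4-yl)methyl or a longer chain such as 2-(pyridin-3-yl)ethyl would keep this level of inhibition.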